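A few compounds are considered here, and "the series" means these few. Any claim that something is new, unique, unknown or untested is made for them only; others in the source may bear on it.

Working notes on the series.

Compound 1 `COc1ccc(OC)c(-c2cc(-c3ccccc3)nn2-c2ccc(S(=O)(=O)NC(C)=O)cc2)c1` gives 15400 nM in a functional assay on cells (Melanoma cell, Homo sapiens) for cytotoxicity, read by sulforhodamine B assay, with a stated time of 48 h; on this read-out lower numbers stand for stronger inhibition of growth and higher numbers for weaker inhibition of growth. Compound 2 `COc1ccc(OC)c(-c2cc(-c3ccc(Cl)cc3)nn2-c2ccc(S(=O)(=O)NC(C)=O)cc2)c1` carries the change chloro in place of hydrogen on an aromatic carbon and gives 10700 nM; the step of a 1.4-fold lower number from compound 1 to compound 2 (0.16 log units; within the scatter) is the only one of this kind so far measured. Compound 3 `Oc1ccc(O)c(-c2cc(-c3ccccc3)nn2-c2ccccc2)c1` gives 22600 nM; the difference between the core of compound 3 and the core of compound 1 is not broken down here, and the values of compound 3 and compound 1 lie within the scatter of each other.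

Compound 4 `Oc1ccc(O)c(-c2cc(-c3ccc(Cl)cc3)nn2-c2ccccc2)c1` repeats the same change on the core of compound 3: chloro in place of hydrogen on an aromatic carbon, placed as in the earlier pair. Going by the values given here, only one step of this kind has been measured, a 1.4-fold lower number from compound 1 to compound 2 (0.16 log units; within the scatter), and it rests on a single pair; a step of about that small size is expected here. For compound 4 the estimate is 16000 nM, between 8000 nM and 32000 nM, meaning an expected step of a 1.4-fold lower number from compound 3 to compound 4 (0.15 log units; within the scatter).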

Compound 4, concentration for 50% growth inhibition: 8790 nM
The estimate for compound 4 lay 1.8-fold (0.26 log units) above the measured number; the range from low to high includes it.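

On the core of compound 3, phenyl to 4-chlorophenyl gives a 2.6-fold lower number from compound 3 to compound 4 (0.41 log units; beyond the scatter) in this assay. Set beside the earlier pair, the size of the step does not differ measurably between the two cores: the same change on two cores in this assay, a 1.4-fold lower number (0.16 log units; within the scatter) from compound 1 to compound 2 and a 2.6-fold lower number (0.41 log units; beyond the scatter) from compound 3 to compound 4, 1.8-fold (0.25 log units) apart, within the scatter of two such steps. The change thus gives a lower number on both cores, although the step on the core of compound 1 lies within the scatter; two pairs do not show that the step depends on the core, or that it carries to any other core.

Still open, as far as these compounds go, is how bromo, an amine or a carboxylic acid would compare with chloro at the same place. Compound 1 and compound 3 differ in more than one place, and the contribution of each difference remains unresolved.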